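Replacing the Aryl Sulfonamide with a Small Nitrile

The source may report more compounds than this note shows. Statements on the series, on what has been measured and on what is new or still open speak of the compounds shown alone.

Four compounds share one core. Compound 1 `CC(C)(N)C(=O)N[C@H](COCc1ccccc1)c1nnn(Cc2ccccc2)n1` gives 1120 nM in a functional assay on H4 cells for agonist activity at growth hormone secretagogue receptor type 1 (Homo sapiens), read by FLIPR; on this read-out lower numbers stand for an effect already at smaller amounts and higher numbers for an effect only at larger amounts of compound. Compound 2 `CC(C)(N)C(=O)N[C@H](COCc1ccccc1)c1nnn(Cc2ccccc2NS(C)(=O)=O)n1` gives 426 nM in this assay, a change of a 2.6-fold lower number from compound 1 to compound 2 (0.42 log units; beyond the scatter). Compound 3 `CC(C)(N)C(=O)N[C@H](COCc1ccccc1)c1nnn(CCCc2ccccc2NS(C)(=O)=O)n1`, carrying the same group on a longer chain, gives 107 nM, the lowest of the three numbers; compound 2 stands nearest and compound 1 furthest. Compound 4 `CC(C)(N)C(=O)N[C@H](COCc1ccccc1)c1nnn(CCCCC#N)n1` carries cyanomethyl in place of 2-(methanesulfonamido)phenyl on a saturated chain carbon, three bonds along the chain from an aromatic nitrogen. Going by the values given here, no measured step removes the whole aromatic ring, but the only step that bears on it, a 2.6-fold lower number from compound 1 to compound 2 (0.42 log units; beyond the scatter), shows how much the methanesulfonamido group alone lowers the number, and compound 4 loses that group and the ring together. A clear rise is therefore expected, estimated as a 14-fold higher number from compound 3 to compound 4 (1.15 log units; beyond the scatter). Compound 4 is expected to give 1500 nM, between 400 nM and 6000 nM.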

Compound 4, half-maximal effective concentration: 1860 nM
Compound 4: middle estimate off by 1.2-fold (0.09 log units), on the low side; measured number inside the range.
By their numbers in this assay, from the lowest: compound 3; then compound 2; then compounds 1 and 4 (each within the scatter of the next).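

In this assay, the long chain does not keep its low number without the 2-(methanesulfonamido)phenyl group: cyanomethyl in its place gives a 17-fold higher number from compound 3 to compound 4 (1.24 log units; beyond the scatter). The nitrile also does not match the shorter sulfonamide, with a 4.4-fold higher number from compound 2 to compound 4 (0.64 log units; beyond the scatter), and the step of a 1.7-fold higher number from compound 1 to compound 4 (0.22 log units; within the scatter) shows that it ends level with the compound lacking the sulfonamide altogether. No measurement here explains why.

Going by these compounds, it remains open whether a plain phenyl ring on the same chain would hold most of the effect, or whether an amine or a carboxylic acid at the chain end could replace the lost group.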